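Series notes: chloro in place of methoxy, compound 4 expected

A few compounds are considered here, and "the series" means these few. Any claim that something is new, unique, unknown or untested is made for them only; others in the source may bear on it.

Measured so far, in a functional assay on U-87MG ATCC cells for antiproliferative activity against U-87 MG (Homo sapiens), read by MTT assay, with a stated time of 48 h, tested at 50 uM; on this read-out higher numbers stand for a weaker effect at the one concentration tested and lower numbers for a stronger effect:
- compound 1 `COc1ccc(-c2nc(SCC(=O)c3sc(-c4ccccc4)nc3C)nc(N)c2C#N)cc1`, compound 1 gives 33.8%
- compound 2 `Cc1nc(-c2ccc(Cl)cc2)sc1C(=O)CSc1nc(-c2ccccc2)c(C#N)c(=O)[nH]1`, compound 2 gives 41.6%
- compound 3 `COc1ccc(-c2nc(C)c(C(=O)CSc3nc(-c4ccc(OC)cc4)c(C#N)c(=O)[nH]3)s2)cc1`, compound 3 gives 32.6%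

Among the measured compounds shown here, of the three numbers, the one for compound 1 sits second highest. Its nearest neighbour is compound 3, whose number is lower by a gap within the scatter, and its furthest is compound 2, whose number is higher by a gap that is also within the scatter. For the measured compounds named here, the three compounds therefore cannot be told apart in this assay on these data, and no step between two compounds that differ in a single place has been measured.

Compound 4 `Cc1nc(-c2ccccc2)sc1C(=O)CSc1nc(N)c(C#N)c(-c2ccc(Cl)cc2)n1` has not yet been measured in this assay. It differs from compound 1 in one place: chloro in place of methoxy on an aromatic carbon. The same change, read one bond further out, is 4-methoxyphenyl to 4-chlorophenyl.

Going by the values given here, with no measured single-place step to lean on, the expectation is that the step of a number 1.2 percentage points higher from compound 1 to compound 4 (within the scatter) stays within the scatter, in no particular direction. Compound 4 is thus estimated at 35%, with an expected range from 22% to 48%.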

Compound 4, a percentage reported as activity, at one concentration (the size of the read-out at that concentration, not a potency): 44.3%
Compound 4: the middle estimate sits 9.3 percentage points below what was measured; measured number inside the range.
By their numbers in this assay, from the lowest: compounds 3, 1, 2 and 4 (each within the scatter of the next, the first and the last beyond it).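

In this assay, among the compounds shown here, the one single-place step available reads a number 10.5 percentage points higher from compound 1 to compound 4 (beyond the scatter), and it is beyond the scatter, whereas compounds 1, 2 and 3 could not be told apart. The position, an aromatic carbon para to a large group, is therefore not indifferent to its substituent: 4-methoxyphenyl to 4-chlorophenyl gives a modest loss of effect at the one concentration tested, since a higher number here stands for a weaker effect, though this says nothing about potency and rests on a single pair. No measurement on hand accounts for the step, which stands as an observation without an explanation.

Open, on these data alone, is whether the loss follows from gaining chloro, from losing methoxy, or from both, a question that the unsubstituted phenyl, fluoro, hydroxy or dimethylamino at the same position would help to separate. Also open, as far as these compounds go, is whether the same change has a comparable effect on the cores of compound 2 and compound 3, which carry a ring carbonyl where compound 1 carries an amine, and whether a full concentration series would keep the difference.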